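The source may hold more compounds than are shown below. What is called first, only, known or untested is meant among the compounds shown, and "the series" means these compounds.

Measured so far in a functional assay on HeLa cells (Homo sapiens) for antiproliferative activity, read by MTT assay, with a stated time of 72 h; on this read-out lower numbers stand for stronger inhibition and higher numbers for weaker inhibition:
- Compound 1 `COc1cccc(N2C(=O)COc3ccc(-c4cnc(OC)c(NS(=O)(=O)c5ccc(F)cc5)c4)cc32)c1`: > 40000 nM
- Compound 2 `COc1ncc(-c2ccc3c(c2)N(C2CCCCC2)C(=O)CO3)cc1NS(=O)(=O)c1ccc(F)cc1`: 6100 nM

Compound 1 gives > 40000 nM as a limit of the assay and not a number. Within the data shown here, compound 2 gives 6100 nM, the only true number so far in this assay. The next compound, compound 3 `COc1ncc(-c2ccc3c(c2)N(c2ccccc2)C(=O)CO3)cc1NS(=O)(=O)c1ccc(F)cc1`, keeps the shared core and changes one group, with phenyl in place of cyclohexyl on an amide-type nitrogen in a ring. Among the measured compounds shown here, one measured step bears on this, at the same nitrogen, where cyclohexyl took the place of 3-methoxyphenyl: an at least 6.5-fold lower number from compound 1 to compound 2 (0.81 log units; beyond the scatter). Phenyl, like 3-methoxyphenyl, is an aromatic ring, so on the strength of that single step a higher number is expected for compound 3, meaning weaker inhibition. The expected change is a 2.5-fold higher number from compound 2 to compound 3 (0.39 log units; beyond the scatter), a modest step beyond the scatter. Compound 3 is estimated at 15000 nM, with an expected range of 5000 nM to 40000 nM.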

Compound 3, half-maximal inhibitory concentration: 1530 nM
The estimate for compound 3 lay 9.8-fold (0.99 log units) above the measured number; measured number below the stated range.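

In this assay, among these compounds, phenyl in place of cyclohexyl on the amide-type nitrogen gives a 4.0-fold lower number from compound 2 to compound 3 (0.60 log units; beyond the scatter) and so an aromatic ring at this nitrogen does not by itself weaken inhibition, which the single earlier step could not show. Hydrogen in place of methoxy on that aromatic ring gives an at least 26-fold lower number from compound 1 to compound 3 (1.41 log units; beyond the scatter) and this ties the weak result of compound 1 to the methoxy group, not to the ring as such. Compound 1 stands at a limit and not a number, so this step gives only a minimum size: the limit of > 40000 nM in this assay, at which 1 of the 3 values shown sits.

The compounds shown leave open whether a fluoro, methyl or amine group on the phenyl ring would weaken inhibition as methoxy does. Also open, as far as these compounds go, is how a benzyl group or a short alkyl chain such as ethyl on this nitrogen would compare with phenyl and cyclohexyl.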